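The source may hold more compounds than are shown below. What is called first, only, known or untested is meant among the compounds shown, and "the series" means these compounds.

Three members of the series stand measured in a functional assay on PC-3 cells (Homo sapiens) for antiproliferative activity, read by MTT assay, with a stated time of 48 h; a lower number here means a stronger inhibitor, a higher number a weaker inhibitor: compound 1 `C#CCOc1ccc(/C=C/C(C)=O)cc1OC` gives 40200 nM, compound 2 `COc1cc(/C=C/C(C)=O)ccc1OCc1cn(-c2c(F)cccc2F)nn1` gives 24200 nM, and compound 3 `COc1cccc(-n2cc(COc3ccc(/C=C/C(C)=O)cc3OC)nn2)c1` gives 31600 nM. By the bare numbers compound 3 is second highest of the three, nearest compound 1 and furthest compound 2, yet both gaps lie within the scatter. Compound 4 `COc1cc(/C=C/C(C)=O)ccc1OCc1cn(-c2ccccc2)nn1` differs from compound 3 by hydrogen in place of methoxy on an aromatic carbon. Among the compounds with values here, the only measured step touching that ring is a 1.3-fold higher number from compound 2 to compound 3 (0.12 log units; within the scatter), and no measured step removes a methoxy, so the change is uncharted. The expected step in this assay is therefore none beyond the scatter, a 1.1-fold lower number from compound 3 to compound 4 (0.02 log units; within the scatter). Compound 4 is estimated at 30000 nM, with a range of 12000 nM to 75000 nM.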

Compound 4, half-maximal inhibitory concentration: 78600 nM
Compound 4: the middle estimate sits 2.6-fold (0.42 log units) below what was measured, outside the stated range (above it).
By their numbers in this assay, from the lowest: compounds 2, 3, 1 and 4 (each within the scatter of the next, the first and the last beyond it).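

In this assay, within the data shown here, removing the methoxy that sits meta to a large group gives the first step beyond the scatter: a 2.5-fold higher number from compound 3 to compound 4 (0.40 log units; beyond the scatter). Removing both fluorines from the 2,6-difluorophenyl gives the same picture, a 3.2-fold higher number from compound 2 to compound 4 (0.51 log units; beyond the scatter), so the bare phenyl of compound 4 stands apart from both substituted rings, while those two rings remain within the scatter of each other. No measured evidence bears on the cause.

From the compounds shown here alone, it remains open whether a hydroxy, an amine or a carboxylic acid at this position would match methoxy. Going by these compounds, the effect of moving methoxy elsewhere on the ring also remains open.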